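Compound 1 to compound 4: butyl for 2-fluorophenyl

The compounds below may be only part of what the source reports. "The series", "measured", "known", "first", "only" and "open" are said of these compounds alone.

- compound 1 `O=C(NCc1cc(Cl)ccc1-n1cnnn1)[C@@H]1CC=NN1C(=O)[C@H](O)c1ccccc1F` gives 8.9 10^-6 cm/s
- compound 2 `O=C([C@H](O)c1ccccc1)N1CC[C@@H]2C[C@@]21C(=O)NCc1cc(Cl)ccc1-n1cnnn1` gives 2.6 10^-6 cm/s
- compound 3 `O=C(NCc1cc(Cl)ccc1-n1cnnn1)[C@@H]1C[C@H]2C[C@H]2N1C(=O)[C@H](O)c1ccccc1` gives 17 10^-6 cm/s

All three values come from an ADME assay on Caco-2 cells (Homo sapiens) for permeability, read by LC-MS, in the apical to basolateral direction, with a stated time of 60 min, at pH 6.5 (on this read-out higher numbers stand for higher permeability and lower numbers for lower permeability), and are the only data for the series. Compound 1 lies within the scatter of compound 3 and beyond the scatter above compound 2. Among the compounds with values here, no two measured compounds differ in one place only, so no measured step is available as a guide.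

Compound 4 `CCCC[C@@H](O)C(=O)N1N=CC[C@H]1C(=O)NCc1cc(Cl)ccc1-n1cnnn1` differs from compound 1 by butyl in place of 2-fluorophenyl on a saturated chain carbon bound to a carbonyl carbon and an oxygen on a saturated carbon. Within the data shown here, no measured compound carries butyl at this place, so the data give no direct reading of this change. The expectation therefore starts from compound 1 at 8.9 10^-6 cm/s and allows for the full spread of the three values, which runs from compound 2 at 2.6 10^-6 cm/s to compound 3 at 17 10^-6 cm/s in this assay.

The estimated step of a 1.1-fold higher number from compound 1 to compound 4 (0.05 log units; within the scatter) is expected to stay within the scatter, with no firm direction. Compound 4 is expected at 10 10^-6 cm/s with an estimated range from 3.5 10^-6 cm/s to 25 10^-6 cm/s in this read-out.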

Compound 4, apparent permeability: 9.8 10^-6 cm/s
Compound 4: middle estimate off by 1.0-fold (0.01 log units), on the high side; measured number inside the range.
By their numbers in this assay, from the lowest: compound 2; then compounds 1, 4 and 3 (each within the scatter of the next).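

In this assay, within the data shown here, butyl in place of 2-fluorophenyl on a saturated chain carbon bound to a carbonyl carbon and an oxygen on a saturated carbon gives a 1.1-fold higher number from compound 1 to compound 4 (0.04 log units; within the scatter), the first comparison in which only one place differs. At this place, therefore, the read-out does not separate a group of 7 heavy atoms with a six-membered aromatic ring of carbon only and a fluorine from an open butyl chain of 4 carbons, so on the core of compound 1 neither that ring nor that fluorine is needed to keep the number where it stands. No measurement on hand accounts for this flat step.

On these data alone, whether the same holds for groups carrying atoms other than carbon at this place, such as an amine or a carboxylic acid, or for a longer chain such as octyl, remains open. Also open, as far as these compounds go, is whether butyl in place of the aromatic group at this place would give an equally small step on another core, such as that of compound 3.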